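The compounds below may be only part of what the source reports. "The series", "measured", "known", "first", "only" and "open" are said of these compounds alone.

Working notes on the series. Three compounds have been run in a functional assay on KM12 cells (Homo sapiens) for inhibition, read by sulforhodamine B assay, with a stated time of 48 h, tested at 100 uM; a higher number here means a weaker effect of the compound at the concentration tested, a lower number a stronger effect. Compound 3 `O=C(Nc1cccc(-n2cc(-c3ccncc3)c(-c3cc(O)cc(Cl)c3)n2)c1)Nc1ccc(Cl)c(Cl)c1` gives -63%. Compound 1 `COc1cc(Cl)cc(-c2nn(-c3cccc(NC(=O)Nc4ccc(Cl)c(C(F)(F)F)c4)c3)cc2-c2ccncc2)c1` gives -70%, and the two values lie within the scatter of each other. Compound 2 `COc1cc(Cl)cc(-c2nn(-c3cccc(NC(=O)c4cccc(C(F)(F)F)c4)c3)cc2-c2ccncc2)c1` gives 28%. On the numbers shown, compound 3 stands second highest of the three, with compound 1 nearest and compound 2 furthest, beyond the scatter. Among the measured compounds shown here, the only single-place step measured is a number 98 percentage points higher from compound 1 to compound 2 (beyond the scatter), a large step that concerns the group on the carbonyl carbon, not the ring substituent that compound 4 alters.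

Compound 4 `COc1cc(Cl)cc(-c2nn(-c3cccc(NC(=O)Nc4ccc(Cl)c(Cl)c4)c3)cc2-c2ccncc2)c1` differs from compound 3 by methyl in place of hydrogen on an oxygen on an aromatic ring, hydroxy to methoxy. For the measured compounds named here, no measured pair isolates this change, so the step from 1 to 2 does not bear on it directly. Going by the values given here, the only guidance is that compound 1 and compound 3 agree within the scatter. Compound 4 is therefore expected to sit close to compound 3, with a number 2 percentage points lower from compound 3 to compound 4 (within the scatter) expected to fall within the scatter. Compound 4 is estimated at -65%, with a range from -85% to -40%.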

Compound 4, a percentage reported as activity, at one concentration (the size of the read-out at that concentration, not a potency): -17%
The estimate for compound 4 lay 48 percentage points below the measured number; the whole stated range lies below it.
By their numbers in this assay, from the lowest: compounds 1 and 3 (each within the scatter of the next); then compound 4; then compound 2.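

Hydroxy to methoxy on the aromatic ring is not a silent change: in this assay it gives a number 46 percentage points higher from compound 3 to compound 4 (beyond the scatter) with the (3,4-dichlorophenyl)amino group held fixed. The closeness of compound 1 and compound 3 therefore does not make hydroxy and methoxy interchangeable, since with methoxy held fixed, chloro in place of trifluoromethyl on an aromatic carbon gives a number 53 percentage points higher from compound 1 to compound 4 (beyond the scatter) and the result at this position depends on that substituent too. The carbonyl substituent still counts with chloro present, as (3,4-dichlorophenyl)amino in place of 3-(trifluoromethyl)phenyl gives a number 45 percentage points lower from compound 2 to compound 4 (beyond the scatter) in the same assay.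

Going by these compounds, how an amino group or an ethoxy chain in place of the hydroxy would read stays open, as does the hydroxy paired with the 4-chloro-3-(trifluoromethyl)phenyl group. No measurement shown here explains these steps.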